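Carboxymethyl amide in place of a butyl ketone

This account rests on a few compounds, and the source may have more. Where it says the series, first, only, none or still open, it means among the compounds named here.

Of the compounds shown here, three that share one core have been tested in an assay on cells for agonist activity at vitamin D3 receptor (Homo sapiens), read by microscopy; on this read-out lower numbers stand for an effect already at smaller amounts and higher numbers for an effect only at larger amounts of compound. Compound 1 `CCn1c(C(=O)NCCC(=O)OC)ccc1C(CC)(CC)c1ccc(C#CC(O)(CC)CC)c(C)c1` gives > 50 nM, which is a limit of the assay and not a number. Compound 2 `CCn1c(C(=O)NCc2ccc(OC)cc2)ccc1C(CC)(CC)c1ccc(C#CC(O)(CC)CC)c(C)c1` likewise gives > 50 nM, again a limit. Compound 3 `CCCCC(=O)c1ccc(C(CC)(CC)c2ccc(C#CC(O)(CC)CC)c(C)c2)n1CC` gives > 50 nM, also a limit. Because all three sit at the limit of > 50 nM in this assay, at which 3 of the 3 values shown sit, the steps a step that the two limits leave unreadable from compound 1 to compound 2, a step that the two limits leave unreadable from compound 1 to compound 3 and a step that the two limits leave unreadable from compound 2 to compound 3 cannot be read in size or direction.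

Compound 4 `CCn1c(C(=O)NCC(=O)O)ccc1C(CC)(CC)c1ccc(C#CC(O)(CC)CC)c(C)c1` has not yet been measured. It differs from compound 3 by (carboxymethyl)amino in place of butyl on a carbonyl carbon. The two measured steps that touch the same carbonyl carbon, from compound 1 and from compound 2 to compound 3, bear on this change, but both are unreadable, so no size or direction can be drawn from them for this assay.

With nothing to read from the neighbours, compound 4 is expected to stay near the same limit, so the step that the limit leaves unreadable from compound 3 to compound 4 is estimated as no change beyond the scatter. Compound 4 is therefore estimated at 120 nM, within a range of 25 nM to 600 nM.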

Compound 4, half-maximal effective concentration: 9.36 nM
For compound 4 the middle estimate is 13-fold (1.11 log units) above the measured one; measured number below the stated range.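

In this assay, the carbonyl carbon now shows a change that can be read, as (carboxymethyl)amino in place of butyl gives an at least 5.3-fold lower number from compound 3 to compound 4 (0.72 log units; beyond the scatter). An amide at this carbon is not enough by itself, since what the amide nitrogen carries also matters: carboxy in place of (methoxycarbonyl)methyl gives an at least 5.3-fold lower number from compound 1 to compound 4 (0.72 log units; beyond the scatter), and carboxy in place of 4-methoxyphenyl gives an at least 5.3-fold lower number from compound 2 to compound 4 (0.72 log units; beyond the scatter). Compound 4 is the only one of the four with a number rather than a limit, so the steps among the other three remain unreadable: the limit of > 50 nM in this assay, at which 3 of the 4 values shown sit.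

The compounds shown do not separate the effect of the free carboxylic acid from that of the chain length, as compound 1 differs from compound 4 in both. A longer chain ending in a carboxylic acid, or a short chain ending in an amine, would help to separate these.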